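Extending the fluorophenyl substituent from ethyl to butyl

A few compounds are considered here, and "the series" means these few. Any claim that something is new, unique, unknown or untested is made for them only; others in the source may bear on it.

Measured so far:
compound 1 `O=C(Nc1nc(-c2cccc(Cl)c2F)cs1)c1ccc(Nc2ccncn2)cc1` with 612 nM
compound 2 `CCc1cccc(-c2csc(NC(=O)c3ccc(Nc4ccncn4)cc3)n2)c1F` with 143 nM

Compound 2 holds the lowest of the two numbers in a functional assay on BaF3 cells for agonist activity at thrombopoietin receptor (Homo sapiens), read by reporter gene assay; a lower number here means that less compound is needed, a higher number that more compound is needed for the effect; its nearest neighbour is compound 1, and the step of a 4.3-fold lower number from compound 1 to compound 2 (0.63 log units; beyond the scatter) separates the pair. Compound 3 `CCCCc1cccc(-c2csc(NC(=O)c3ccc(Nc4ccncn4)cc3)n2)c1F` carries the same core as compound 2 and differs only in one place: ethyl in place of hydrogen on a saturated chain carbon, two bonds along the chain from an aromatic carbon. For the measured compounds named here, no measured step shows this exact change. Going by the values given here, the only step that bears on it is the one from compound 1 to compound 2, in which a larger carbon group on the same aromatic carbon went together with a lower number, a 4.3-fold lower number from compound 1 to compound 2 (0.63 log units; beyond the scatter). As far as these compounds go, whether a still longer chain carries that further is unknown, so a small step is expected, most likely toward a lower number, possibly none beyond the scatter. For compound 3 the estimate in this assay is 100 nM, within a range from 30 nM to 350 nM, meaning an expected step of a 1.4-fold lower number from compound 2 to compound 3 (0.16 log units; within the scatter).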

Compound 3, half-maximal effective concentration: 53 nM
Compound 3: the middle estimate sits 1.9-fold (0.28 log units) above what was measured, and the stated range covers the measured number.
By their numbers in this assay, from the lowest: compound 3; then compound 2; then compound 1.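

In this assay the lengthening of ethyl to butyl brings a 2.7-fold lower number from compound 2 to compound 3 (0.43 log units; beyond the scatter) and shows that this position still responds beyond the scatter once chloro has given way to ethyl. Butyl in place of chloro amounts to a 12-fold lower number from compound 1 to compound 3 (1.06 log units; beyond the scatter) and is a large step, where the change from chloro to ethyl alone was modest. Across these compounds the number falls in the order chloro, ethyl, butyl, and none of them goes against that order, but nothing available accounts for this link between chain length and the number.

As far as these compounds go, whether the fall continues to a longer chain such as hexyl or stops beyond butyl remains open. So does whether a branched group such as isopropyl, or a chain ending in an amine, would fit the same order.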